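From compound 2 to compound 3: one group exchanged

The source may hold more compounds than are shown below. What is called first, only, known or untested is meant among the compounds shown, and "the series" means these compounds.

Of the compounds shown here, two have been measured so far, compound 1 (`Cc1cccc(C)c1-c1cccc(COc2ccc(SCC(=O)O)cc2)c1`) and compound 2 (`Cc1ccccc1-c1cccc(COc2ccc(S(=O)(=O)CC(=O)O)cc2)c1`). In a physicochemical assay for lipophilicity, using the shake flask method, in phosphate buffer, measured as octanol-water partition, with a stated time of 24 h, at pH 7.4, tested at 100 uM (on this read-out higher numbers stand for higher lipophilicity and lower numbers for lower lipophilicity), compound 1 gives 3.82, while compound 2 gives 2.35. Compound 2 therefore holds the lower of the two numbers, and the gap between them lies beyond the scatter of the measurement. Going by the values given here, no measured pair differs in one place only, so no measured step is available as a guide.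

Compound 3 (`Cc1ccc(-c2cccc(COc3ccc(S(=O)(=O)CC(=O)O)cc3)c2)c(Cl)c1`) has yet to be measured. It departs from compound 2 in one place, with 2-chloro-4-methylphenyl in place of 2-methylphenyl on an aromatic carbon. The expectation rests on this structural change alone, and so it is uncertain. Starting from compound 2 at 2.35, a moderate rise beyond the scatter is expected in this assay. The expected step is a number 0.75 log units higher from compound 2 to compound 3 (beyond the scatter). For compound 3 the estimated value is 3.1, with an expected range of 2.6 to 3.6.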

Compound 3, distribution coefficient: 3.05
Estimate against measurement, compound 3: 0.05 log units above, within the range that was stated.
By their numbers in this assay, from the lowest: compound 2; then compound 3; then compound 1.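

In this assay, going by these compounds alone, the exchange of 2-methylphenyl for 2-chloro-4-methylphenyl, on an aromatic carbon meta to a large group, gives a number 0.70 log units higher from compound 2 to compound 3 (beyond the scatter) and so provides the first step that can be read at a single place. Compound 1 and compound 2 differ in more than one place, so their gap could not be tied to this position; the new step shows that this position alone can shift the read-out beyond the scatter, here in a modest step. The entering and leaving groups both count no hydrogen-bond donors, no hydrogen-bond acceptors and no net charge, and nothing measured here explains the size of the step.

The compounds shown leave open how much of the step belongs to the chlorine and how much to the methyl, as the two names differ in both, and a single exchange cannot separate them. Also open, on these data alone, is how the read-out would answer at this position to a group of another kind, such as an amine, a methoxy group or a carboxylic acid on the same ring.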